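The source may hold more compounds than are shown below. What is called first, only, known or untested is meant among the compounds shown, and "the series" means these compounds.

The measured compounds in a physicochemical assay for acid dissociation:
Compound 1 `COc1cccc(Oc2ccc3c(NCCCNCc4cc(F)ccc4OC)ccnc3c2)c1` gives 9.28.
Compound 2 `Cc1cc(C)cc(Cc2ccc3c(NCCCNCc4ccco4)ccnc3c2)c1` gives 9.47.
Compound 3 `COc1cccc(Oc2ccc3c(NCCCNCc4cccc(OC)c4O)ccnc3c2)c1` gives 9.28.

In this assay compound 1 stands level with compound 3 at the digits shown, and the two of them are the lowest of the three numbers; compound 2 lies higher by an amount that remains within the scatter, so no order can be read among the three.

Compound 4 `COc1ccc(F)cc1CNCCCNc1ccnc2cc(Cc3ccccc3)ccc12` has not yet been measured. It differs from compound 1 in one place: benzyl in place of 3-methoxyphenoxy on an aromatic carbon.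

Within the data shown here, only one measured step is known, no change at the digits printed from compound 1 to compound 3 (within the scatter), and it concerns the group on the saturated chain carbon bound to the amine nitrogen, not the position changed here. Among the measured compounds shown here, compound 2, whose structure lacks the 3-methoxyphenoxy group, shows a value within the scatter of compound 1, which suggests that the group at this position matters little for this assay, though no step between compound 1 and compound 2 has been computed.

Compound 4 is therefore expected to give 9.35, between 9 and 9.7. The expected step of a number 0.07 log units higher from compound 1 to compound 4 (within the scatter) is estimated to lie within the scatter.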

Compound 4, acid dissociation constant: 9.47
Estimate against measurement, compound 4: 0.12 log units below; the measured number falls inside the stated range.
By their numbers in this assay, from the lowest: compounds 1, 3, 2 and 4 (each within the scatter of the next).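

In this assay, among these compounds, the first direct step at this aromatic carbon, benzyl in place of 3-methoxyphenoxy, gives a number 0.19 log units higher from compound 1 to compound 4 (within the scatter), so the read-out does not separate these two groups, whereas the earlier step concerned only the group on the saturated chain carbon. The change removes the hydrogen-bond acceptors of the leaving group and leaves a smaller group, while a six-membered aromatic ring of carbon only stays in place on both sides, and this exchange still falls within the scatter. No measurement shown here offers an explanation for this result.

The compounds shown cover only benzyl and 3-methoxyphenoxy on this carbon, both of which carry a six-membered aromatic ring of carbon only, so it stays open whether a group without such a ring, such as an amine or a carboxylic acid, would also stay within the scatter of compound 1. Going by these compounds, it is equally open whether a longer chain between this carbon and the ring would do the same, and a single step cannot show how far the result extends to other compounds.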